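The source may hold more compounds than are shown below. What is called first, only, known or untested is meant among the compounds shown, and "the series" means these compounds.

Compound 1 `COc1cccc(/C=C/C(=O)c2ccc(OC)c3c2OC(C)(C)C=C3)c1`: > 10000 nM in a functional assay on HCT-116 cells (Homo sapiens) for antiproliferative activity, read by MTT assay, with a stated time of 24 h (on this read-out higher numbers stand for weaker inhibition and lower numbers for stronger inhibition), a limit of the assay.
Compound 2 `COc1ccc(C(=O)/C=C/c2cccc([N+](=O)[O-])c2)c2c1C=CC(C)(C)O2`: 8050 nM.
Compound 3 `COc1ccc(C(=O)/C=C/c2cccc(O)c2)c2c1C=CC(C)(C)O2`: > 10000 nM, also a limit.

Compound 1 thus stands only at the limit of > 10000 nM in this assay, at which 2 of the 3 values shown sit, without a numeric reading. Compound 4 `COc1ccc(C(=O)/C=C/c2cc(Cl)ccc2O)c2c1C=CC(C)(C)O2` differs from it by 5-chloro-2-hydroxyphenyl in place of 3-methoxyphenyl on a double-bonded chain carbon bound to a double-bonded chain carbon. Among the measured compounds shown here, two measured steps bear on this change: a step that the two limits leave unreadable from compound 1 to compound 3, where one limit meets another, and an at least 1.2-fold higher number from compound 2 to compound 3 (0.09 log units; that floor lies within the scatter), whose floor lies within the scatter. Neither gives a usable size, so no step beyond the scatter is expected in this assay, and the limit may well recur. Compound 4 is therefore estimated at 9000 nM, in a range from 3000 nM to 30000 nM. That estimate means an expected at least 1.1-fold lower number from compound 1 to compound 4 (0.04 log units; that floor lies within the scatter).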

Compound 4, half-maximal inhibitory concentration: 5240 nM
Estimate against measurement, compound 4: 1.7-fold (0.23 log units) above; measured number inside the range.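

Compound 1 and compound 3 each stay at a limit in this assay: the limit of > 10000 nM in this assay, at which 2 of the 4 values shown sit. With 5-chloro-2-hydroxyphenyl at this place the series gains a second numeric reading, and the change brings an at least 1.9-fold lower number from compound 1 to compound 4 (0.28 log units; that floor lies within the scatter) and an at least 1.9-fold lower number from compound 3 to compound 4 (0.28 log units; that floor lies within the scatter). Set against 3-nitrophenyl it gives a 1.5-fold lower number from compound 2 to compound 4 (0.19 log units; within the scatter), so no step at this place yet clears the scatter. The compounds shown do not separate the chlorine from the hydroxy of the entering group. On these data alone, how an amine or a carboxylic acid in their stead would read in this assay also stays open.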